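Swapping Nitro for Chloro on Two Related Cores

A few compounds are considered here, and "the series" means these few. Any claim that something is new, unique, unknown or untested is made for them only; others in the source may bear on it.

Compound 1 `Clc1ccc(Nc2ccc(N3CC4CC(C3)N4)cn2)cc1` and compound 2 `O=[N+]([O-])c1ccc(Nc2ccc(N3CC4CC(C3)N4)cn2)cc1` are built on one shared core, while compound 3 `O=[N+]([O-])c1ccc(Nc2ccc(N3CC4CC(C3)N4)nn2)cc1` and compound 4 `Clc1ccc(Nc2ccc(N3CC4CC(C3)N4)nn2)cc1` are built on another. In an assay on cell membranes for displacement of a labelled ligand from Neuronal acetylcholine receptor; alpha4/beta2 (Rattus norvegicus) (on this read-out higher numbers stand for weaker inhibition and lower numbers for stronger inhibition), compound 1 gives 2.49 nM, and compound 2 gives 1.76 nM. The change between them, (chloro in place of nitro on an aromatic carbon), produced a 1.4-fold higher number from compound 2 to compound 1 (0.15 log units; within the scatter). In this assay compound 3 gives 86.2 nM; the difference between the two cores is not broken down here. Compound 4 carries the same change as compound 1, (chloro in place of nitro on an aromatic carbon), at the same place. Because the step of a 1.4-fold higher number from compound 2 to compound 1 (0.15 log units; within the scatter) was small, the step of a 1.3-fold higher number from compound 3 to compound 4 (0.13 log units; within the scatter) is expected to be small as well. Compound 4 is therefore estimated to give 115 nM in this assay, most likely between 50 nM and 260 nM.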

Compound 4, inhibition constant: 90.4 nM
For compound 4 the middle estimate is 1.3-fold (0.10 log units) above the measured one; the range from low to high includes it.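

In this assay, chloro in place of nitro on the second core gave a 1.0-fold higher number from compound 3 to compound 4 (0.02 log units; within the scatter), so here too the swap made no difference beyond the scatter. The change behaved alike on both cores: the same change on two cores in this assay, a 1.4-fold higher number (0.15 log units; within the scatter) from compound 2 to compound 1 and a 1.0-fold higher number (0.02 log units; within the scatter) from compound 3 to compound 4, 1.3-fold (0.13 log units) apart, within the scatter of two such steps. This shows that, for these two pairs, the small step carried over from one core to the other, but it does not show that it would carry over to any further core, and it does not explain why the two groups give such similar numbers.

From the compounds shown here alone, it remains open whether an amine or a carboxylic acid at the same place would also give matching steps on both cores. The same question stands for a longer chain there.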